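Ester to ether on the side-chain oxygen: compound 4

This account rests on a few compounds, and the source may have more. Where it says the series, first, only, none or still open, it means among the compounds named here.

Measured so far:
compound 1, `CC(C)=CC[C@@H](OC(=O)CCO)C1=CC(=O)c2c(O)ccc(O)c2C1=O`, 55300 nM
compound 2, `CCCCC(O)CC(=O)O[C@H](CC=C(C)C)C1=CC(=O)c2c(O)ccc(O)c2C1=O`, 45300 nM
compound 3, `CCCC(C)(O)CC(=O)O[C@H](CC=C(C)C)C1=CC(=O)c2c(O)ccc(O)c2C1=O`, 75000 nM

All three numbers come from a functional assay on DU-145 cells (Homo sapiens) for cytotoxicity, read by MTT assay; a higher number here means a weaker inhibitor, a lower number a stronger inhibitor. Compound 1 stands with its number between those of the other two: the nearest is compound 2, a 1.2-fold lower number from compound 1 to compound 2 (0.09 log units; within the scatter), and the furthest is compound 3, a 1.4-fold higher number from compound 1 to compound 3 (0.13 log units; within the scatter). The third pair, a 1.7-fold higher number from compound 2 to compound 3 (0.22 log units; within the scatter), is likewise within the scatter, so the three measured compounds cannot be told apart on these numbers.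

Compound 4, `CC(C)=CC[C@@H](OCCO)C1=CC(=O)c2c(O)ccc(O)c2C1=O`, is not yet measured. It differs from compound 1 in a single place: 2-hydroxyethyl in place of (2-hydroxyethyl)carbonyl on an oxygen on a saturated carbon. Within the data shown here, the measured steps all alter the acyl chain while leaving the ester itself in place; none of them touches the oxygen on a saturated carbon in the way the change to compound 4 does, so no measured step speaks directly to it. What the steps do show is that changes around this part of the molecule, from hydrogen to butyl and from hydroxymethyl to 1-hydroxy-1-methylbutyl, left the number within the scatter each time.

On that basis a step of a 1.0-fold lower number from compound 1 to compound 4 (0.00 log units; within the scatter) is expected, that is, none beyond the scatter, and the number for compound 4 in this assay is estimated at 55000 nM with a range from 20000 nM to 150000 nM.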

Compound 4, half-maximal inhibitory concentration: 9900 nM
For compound 4 the middle estimate is 5.6-fold (0.74 log units) above the measured one, and the stated range ends above it.
By their numbers in this assay, from the lowest: compound 4; then compounds 2, 1 and 3 (each within the scatter of the next).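

In this assay, among these compounds, replacing (2-hydroxyethyl)carbonyl with 2-hydroxyethyl on an oxygen on a saturated carbon gives a 5.6-fold lower number from compound 1 to compound 4 (0.75 log units; beyond the scatter), the first step in this set that lies beyond the scatter. The ether also separates from the two esters with longer acyl groups, with a 4.6-fold lower number from compound 2 to compound 4 (0.66 log units; beyond the scatter) and a 7.6-fold lower number from compound 3 to compound 4 (0.88 log units; beyond the scatter), whereas compound 1, compound 2 and compound 3 remain within the scatter of one another. This position therefore responds to a change at the link itself, while the acyl-chain changes shown among the esters leave the number unresolved, and compound 4 has the lowest number of the four, beyond the scatter from each of the others.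

The change removes the carbonyl and also shortens the group on the oxygen, so these two contributions remain tied together, and a 3-hydroxypropyl ether on the same oxygen would separate them, while an ethyl ether or a 2-aminoethyl ether would test what the terminal hydroxyl contributes. No supporting measurement is available to account for the size of this step.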